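A few compounds are considered here, and "the series" means these few. Any claim that something is new, unique, unknown or untested is made for them only; others in the source may bear on it.

Measured compounds:
- compound 1, `Cc1cc(O)cc(-c2nn(CC#N)cc2-c2ccnc(-c3ccc(Oc4ccccc4)cc3)c2)c1`: 24700 nM
- compound 2, `COc1cc(C)cc(-c2nn(CC#N)cc2-c2ccnc(-c3ccc(N(C)C)cc3)c2)c1`: 18700 nM

Of the compounds shown here, two have been measured in a functional assay on HOP-62 cells (Homo sapiens) for inhibition, read by sulforhodamine B assay, with a stated time of 48 h; on this read-out lower numbers stand for stronger inhibition of growth and higher numbers for weaker inhibition of growth. Compound 1, `Cc1cc(O)cc(-c2nn(CC#N)cc2-c2ccnc(-c3ccc(Oc4ccccc4)cc3)c2)c1`, gives 24700 nM in this assay. Compound 2, `COc1cc(C)cc(-c2nn(CC#N)cc2-c2ccnc(-c3ccc(N(C)C)cc3)c2)c1`, gives 18700 nM. Compound 2 has the lower number of the two, but the gap to compound 1 is within the scatter, so the two values cannot be placed in order; they show that both compounds inhibit growth to a similar degree. Among the compounds with values here, compound 1 and compound 2 differ in more than one place, so no single step connects them.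

The compound not yet measured is compound 3, `Cc1cc(O)cc(-c2nn(CC#N)cc2-c2ccnc(-c3ccc(N(C)C)cc3)c2)c1`. It differs from compound 2 in one place: hydrogen in place of methyl on an oxygen on an aromatic ring. Within the data shown here, no measured pair shows this change on its own, so there is no step to draw on. Compound 1 carries the same hydroxy group and gives a value close to that of compound 2, which is the only hint available. The expected step from compound 2 to compound 3 is therefore none beyond the scatter, a 1.0-fold higher number from compound 2 to compound 3 (0.01 log units; within the scatter). Compound 3 is estimated at 19000 nM, within a range of 8000 nM to 45000 nM.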

Compound 3, concentration for total growth inhibition: 23400 nM
Compound 3: middle estimate off by 1.2-fold (0.09 log units), on the low side; the range from low to high includes it.
By their numbers in this assay, from the lowest: compounds 2, 3 and 1 (each within the scatter of the next).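

Within the data shown here, with compound 3 in hand, the exchange of methoxy for hydroxy on the 3-methoxy-5-methylphenyl group can be read on its own for the first time: in this assay it gives a 1.3-fold higher number from compound 2 to compound 3 (0.10 log units; within the scatter), a step that cannot be told from the scatter. Among these compounds, compound 3 also gives the first single-place reading for the other end of the molecule, where dimethylamino stands in place of phenoxy on an aromatic carbon, with a 1.1-fold lower number from compound 1 to compound 3 (0.02 log units; within the scatter), again within the scatter. Neither change therefore separates these compounds in this growth read-out, and the three values give no ranking among compound 1, compound 2 and compound 3. No measurement at hand bears on this result.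

The compounds shown leave open whether a different group on that aromatic ring, such as an amine or a carboxylic acid, or a longer alkoxy chain on the oxygen, would give a number beyond the scatter. They also leave open whether these two changes would read the same way in cells other than the HOP-62 line.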